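The source may report more compounds than this note shows. Statements on the series, on what has been measured and on what is new or still open speak of the compounds shown alone.

Working notes on the sulfur-linked nucleoside series

Three compounds have numbers in an assay on isolated protein for binding affinity to Equilibrative nucleoside transporter 1 (Homo sapiens); a lower number here means a stronger inhibitor, a higher number a weaker inhibitor. Compound 1 `O=[N+]([O-])c1cccc2c1CN(c1ncnc3c1nc1n3[C@@H]3O[C@H](CO1)[C@@H](O)[C@H]3O)CC2` gives 1740000 nM. Compound 2 `OC[C@H]1O[C@@H](n2cnc3c(SCC4CCCCC4)ncnc32)[C@H](O)[C@@H]1O` gives 1550 nM. Compound 3 `OC[C@H]1O[C@@H](n2cnc3c(CSc4ccccc4Br)ncnc32)[C@H](O)[C@@H]1O` gives 2400 nM. On these numbers compound 3 stands second highest of the three: its nearest neighbour is compound 2, within the scatter, and its furthest is compound 1, far beyond it. Within the data shown here, the only measured step in which one group on the sulfur is exchanged for another, a 1.5-fold higher number from compound 2 to compound 3 (0.19 log units; within the scatter), stays within the scatter.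

Compound 4 `COc1ccc(SCc2ncnc3c2ncn3[C@@H]2O[C@H](CO)[C@@H](O)[C@H]2O)cc1` differs from compound 3 by 4-methoxyphenyl in place of 2-bromophenyl on a sulfur. That change again exchanges one group on the sulfur while the rest of compound 3 is kept, so the step already noted is the one that bears on it, and it was small. No step beyond the scatter is therefore expected; the estimated step of a 1.1-fold lower number from compound 3 to compound 4 (0.04 log units; within the scatter) is taken as flat. For compound 4 the expected number in this assay is 2200 nM, with a range estimated from 700 nM to 7000 nM.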

Compound 4, half-maximal inhibitory concentration: 617 nM
Estimate against measurement, compound 4: 3.6-fold (0.55 log units) above; measured number outside the range, below it.
By their numbers in this assay, from the lowest: compound 4; then compounds 2 and 3 (each within the scatter of the next); then compound 1.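

In this assay, the group on the sulfur now makes a measurable difference: 4-methoxyphenyl in place of 2-bromophenyl gives a 3.9-fold lower number from compound 3 to compound 4 (0.59 log units; beyond the scatter), whereas the earlier exchange of groups on sulfur gave a 1.5-fold higher number from compound 2 to compound 3 (0.19 log units; within the scatter) and stayed within the scatter. This position therefore tolerates more than a flat response, and of the aryl groups on this sulfur, 4-methoxyphenyl carries the lower number. No measurement in hand accounts for the step.

The step changes the substituent and its place on the phenyl ring together, so the compounds shown do not separate the two. They also leave open how an unsubstituted phenyl, a 4-bromophenyl, a 2-methoxyphenyl or a 4-aminophenyl on the same sulfur would read.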